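This account rests on a few compounds, and the source may have more. Where it says the series, first, only, none or still open, it means among the compounds named here.

Compound 1 `O=C(O)c1cc(-c2ccc(-c3ccc(Cl)cc3Cl)cc2)n(-c2ccccn2)n1` sits at the assay limit in an assay on isolated protein for inhibition of methionine--tRNA ligase, cytoplasmic (Homo sapiens) (a lower number here means a stronger inhibitor, a higher number a weaker inhibitor), giving > 100000 nM.
Compound 2 `COc1ccc(-n2nc(C(=O)O)cc2-c2ccc(-c3ccc(Cl)cc3Cl)cc2)cc1` also gives only a limit in this assay, > 100000 nM.
Compound 3 `O=C(O)c1cc(-c2ccc(-c3ccccc3)cc2)n(-c2ccc(Cl)cc2Cl)n1` gives 44300 nM in this assay.

Within the data shown here, compound 3 is therefore the only compound with a measured number; the other two sit at the limit of > 100000 nM in this assay, at which 2 of the 3 values shown sit. Among the measured compounds shown here, the one step between measured compounds, a step that the two limits leave unreadable from compound 1 to compound 2, is unreadable because both its ends are limits, and it concerns a different position from the change now considered. Compound 4 `O=C(O)c1cc(-c2ccc(-c3ccc(C(F)(F)F)cc3)cc2)n(-c2ccc(Cl)cc2Cl)n1` differs from compound 3 by trifluoromethyl in place of hydrogen on an aromatic carbon. For the measured compounds named here, no measured step bears on this change, so for compound 4 a step of a 1.1-fold lower number from compound 3 to compound 4 (0.04 log units; within the scatter) is expected, with nothing beyond the scatter in either direction. Compound 4 is estimated at 40000 nM, between 10000 nM and 150000 nM.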

Compound 4, half-maximal inhibitory concentration: 33500 nM
The estimate for compound 4 lay 1.2-fold (0.08 log units) above the measured number; the range from low to high includes it.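

With a 1.3-fold lower number from compound 3 to compound 4 (0.12 log units; within the scatter), the series gains its first readable step, and it shows that trifluoromethyl can replace hydrogen on this aromatic carbon, para to a large group, without a change beyond the scatter. Among these compounds, the only earlier step has a limit at both ends and cannot be read. As far as these compounds go, whether an amine or a nitrile on this same carbon would move the number beyond the scatter remains open. Compounds 1 and 2 offer no number to compare, only an assay limit: the limit of > 100000 nM in this assay, at which 2 of the 4 values shown sit.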